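One Methyl Group on Two Weak Inhibitors

A few compounds are considered here, and "the series" means these few. Any claim that something is new, unique, unknown or untested is made for them only; others in the source may bear on it.

Compound 1 `COc1cc(O)cc(O)c1C(=O)/C=C/c1ccc(O)cc1` and compound 2 `COc1ccc(/C=C/C(=O)c2c(O)cc(O)cc2OC)cc1` share one core, and compound 2 carries methyl in place of hydrogen on an oxygen on an aromatic ring. In a functional assay on HeLa cells (Homo sapiens) for inhibition, read by MTT assay, with a stated time of 72 h (a lower number here means a stronger inhibitor, a higher number a weaker inhibitor), compound 1 gives 48100 nM. In this assay compound 2 gives 47700 nM, so that a 1.0-fold lower number from compound 1 to compound 2 (0.00 log units; within the scatter). Compound 3 `COc1cc(/C=C/C(=O)c2c(O)cc(O)cc2OC)ccc1O` differs from compound 1 by methoxy in place of hydrogen on an aromatic carbon. In this assay compound 3 reaches only a limit of the assay, reported as > 50000 nM. The step of an at least 1.0-fold higher number from compound 1 to compound 3 (0.01 log units; that floor lies within the scatter) therefore cannot be sized more closely, since compound 3 sits at the limit of > 50000 nM in this assay, at which 1 of the 3 values shown sits.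

Compound 4 `COc1ccc(/C=C/C(=O)c2c(O)cc(O)cc2OC)cc1OC` has not yet been measured. Compared with compound 3 it carries methyl in place of hydrogen on an oxygen on an aromatic ring, which is the same change as the one from compound 1 to compound 2, made at the same place. Because that earlier change gave a 1.0-fold lower number from compound 1 to compound 2 (0.00 log units; within the scatter), compound 4 is expected to show a step that the limit leaves unreadable from compound 3 to compound 4, which would leave it at or near the limit of this assay. Compound 4 is therefore estimated at 55000 nM, with a likely range from 25000 nM to 120000 nM.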

Compound 4, half-maximal inhibitory concentration: 49500 nM
Compound 4: middle estimate off by 1.1-fold (0.05 log units), on the high side; the measured number falls inside the stated range.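

In this assay, methoxy in place of hydrogen on an aromatic carbon can be followed on two cores, and the new step on the core of compound 2 is a 1.0-fold higher number from compound 2 to compound 4 (0.02 log units; within the scatter), so this change carries across without a step that stands out from the scatter, as far as the limit allows the two to be compared: (the same change on two cores in this assay, an at least 1.0-fold higher number (0.01 log units; that floor lies within the scatter) from compound 1 to compound 3 and a 1.0-fold higher number (0.02 log units; within the scatter) from compound 2 to compound 4; the limit leaves it open whether they differ). The methyl in place of hydrogen on an oxygen on an aromatic ring cannot be followed in the same way, and the step that starts from compound 3 cannot be read, since compound 3 stands only at a limit of the assay. The step of a number no higher from compound 3 to compound 4 (the limit leaves the size open) does not show that the methyl change carries from one core to the other, and it does not show that the two instances differ: (the same change on two cores in this assay, a 1.0-fold lower number (0.00 log units; within the scatter) from compound 1 to compound 2 and a number no higher (the limit leaves the size open) from compound 3 to compound 4; the limit leaves it open whether they differ).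

The compounds shown leave open what an amine, a carboxylic acid or a longer chain such as ethoxy would do on the shared core. They also leave open whether either change would behave alike on a compound with a much lower number in this assay.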